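This account rests on a few compounds, and the source may have more. Where it says the series, first, only, none or still open, it means among the compounds named here.

Working notes on the series. Compound 1 `Cc1nsc2[nH]c(SCc3ccccc3)nc12` in a functional assay on HFF cells (Homo sapiens) for inhibition (a lower number here means a stronger inhibitor, a higher number a weaker inhibitor), gives 10000 nM. Compound 2 `c1ccc(CSc2nc3cnsc3[nH]2)cc1` in this assay gives 14000 nM, after a step of a 1.4-fold higher number from compound 1 to compound 2 (0.15 log units; within the scatter). Among the two numbers measured, compound 2 stands at the upper one, with compound 1 the nearest, and that gap lies within the scatter. Compound 3 `Cc1nsc2c1ncn2[C@H]1C[C@H](O)[C@@H](CO)O1` in this assay gives > 100000 nM, which is a limit of the assay and not a number. That entry is the limit of > 100000 nM in this assay, at which 1 of the 3 values shown sits.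

Compound 4 `OC[C@H]1O[C@@H](n2c(SCc3ccccc3)nc3cnsc32)C[C@@H]1O` is not yet measured. It differs from compound 2 by 4-hydroxy-5-(hydroxymethyl)oxolan-2-yl in place of hydrogen on an aromatic nitrogen. Among the compounds with values here, no measured step covers this change: the single step measured, from compound 1 to compound 2, concerns a methyl and sits within the scatter. Compound 3, which also carries a 4-hydroxy-5-(hydroxymethyl)oxolan-2-yl group, gives only a limit, but it differs from compound 2 in more than one place, so only its value is noted. The expected step for compound 4 is therefore set as a 2.1-fold higher number from compound 2 to compound 4 (0.33 log units; beyond the scatter), toward a higher number, with wide uncertainty. Compound 4 is estimated at 30000 nM, in the range 8000 nM to 100000 nM.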

Compound 4, half-maximal inhibitory concentration: > 100000 nM
Compound 4: no number, only a limit; the forecaster's own chance of this, stated with the estimate: 40%; middle value at least 3.3-fold (0.52 log units) away from the limit.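

Replacing hydrogen on this aromatic nitrogen with 4-hydroxy-5-(hydroxymethyl)oxolan-2-yl, with the benzylsulfanyl group kept, gives a step beyond the scatter in this assay: an at least 7.1-fold higher number from compound 2 to compound 4 (0.85 log units; beyond the scatter). Within the data shown here, the earlier step, a 1.4-fold higher number from compound 1 to compound 2 (0.15 log units; within the scatter), concerned only a methyl on an aromatic carbon, so this is the first indication that the series is sensitive to a change at the ring nitrogen, and the change moves the number upward. The entry for compound 4 is a limit of the assay and not a number: the limit of > 100000 nM in this assay, at which 2 of the 4 values shown sit.

The compounds shown leave open whether any group on this nitrogen raises the number or only this oxolane group does, as a methyl or a 2-hydroxyethyl chain there might tell. They also leave open which part of the group matters, the ring itself or its hydroxy and hydroxymethyl groups.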